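A few compounds are considered here, and "the series" means these few. Any claim that something is new, unique, unknown or untested is made for them only; others in the source may bear on it.

Compound 1 `Cc1ccccc1S(=O)(=O)Nc1ccc2oc(-c3ccccc3)nc2c1` gives in an assay on isolated protein for inhibition of malate dehydrogenase, mitochondrial (Sus scrofa), with stated times of 45 min and 30 min (on this read-out higher numbers stand for weaker inhibition and lower numbers for stronger inhibition), a value of > 63000 nM, which is a limit of the assay and not a number.
Compound 2 `COc1cccc(S(=O)(=O)Nc2ccc3oc(-c4ccccc4)nc3c2)c1` gives in this assay a value of > 63000 nM, again only a limit.
Compound 3 `COc1ccccc1S(=O)(=O)Nc1ccc2oc(-c3ccccc3)nc2c1` gives in this assay a value of > 63000 nM, likewise only a limit.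

Compound 3 therefore stands exactly where the other two measured compounds stand, namely at the limit of > 63000 nM in this assay, at which 3 of the 3 values shown sit. The change to compound 4 `O=S(=O)(Nc1ccc2oc(-c3ccccc3)nc2c1)c1ccccc1C(F)(F)F` is trifluoromethyl in place of methoxy on an aromatic carbon. The measured steps that end at compound 3, a step that the two limits leave unreadable from compound 1 to compound 3 and a step that the two limits leave unreadable from compound 2 to compound 3, bear on this change, as does a step that the two limits leave unreadable from compound 1 to compound 2, but all three are hidden by the limit, so none gives a size or a direction. Nothing measured here points to an inhibitor of readable strength, and the expectation for compound 4 in this assay is a step that the limit leaves unreadable from compound 3 to compound 4, that is, no step beyond the scatter. Compound 4 is thus estimated at 80000 nM, within 30000 nM to 250000 nM, most likely reported again only as a limit.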

Compound 4, half-maximal inhibitory concentration: > 63000 nM
Compound 4 was reported as a limit; the forecaster's own chance of this, stated with the estimate: 85%; the middle value lies beyond the limit too.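

The steps from compound 3 to compound 4 and from compound 1 to compound 4 cannot be read in this assay, as compound 4 also gives only a limit: the limit of > 63000 nM in this assay, at which 4 of the 4 values shown sit.

The compounds shown leave open how methyl, methoxy and trifluoromethyl compare on an aromatic carbon, and whether any of them gives readable inhibition.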